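The source may report more compounds than this note shows. Statements on the series, on what has been measured and on what is new or still open speak of the compounds shown alone.

In an ADME assay on HepG2 cells (Homo sapiens) for cytotoxicity, read by XTT assay, with a stated time of 48 h (on this read-out lower numbers stand for higher toxicity in this test and higher numbers for lower toxicity in this test), compound 1 (`CCCCCCCCC[C@@H]1CC(O)=C(C(=O)CCC)C(=O)O1`) gives 33 ug/mL. Among the measured compounds shown here, the only other measured compound, compound 2 (`CCCCCCCCCC[C@@H]1CC(O)=C(C(=O)CCC)C(=O)O1`), gives 25 ug/mL, so the two values lie within the usual scatter of repeated measurements and cannot be told apart. Compound 3 (`CCCCCCCCCCC[C@@H]1CC(O)=C(C(=O)CCC)C(=O)O1`) has not been measured yet. It keeps the core of compound 1 and differs only in the chain: ethyl in place of hydrogen on a saturated chain carbon, nine bonds along the chain from a saturated ring carbon. For the measured compounds named here, one measured step bears on this change. Methyl in place of hydrogen on that same chain carbon gave a 1.3-fold lower number from compound 1 to compound 2 (0.12 log units; within the scatter). Going by the values given here, with only this small step to go on, ethyl is not expected to move the number clearly beyond the scatter in this assay, though any drift would most likely follow that step's direction. The expected result is a 1.5-fold lower number from compound 1 to compound 3 (0.18 log units; within the scatter). Compound 3 is therefore estimated at 22 ug/mL, with an expected range of 11 ug/mL to 42 ug/mL.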

Compound 3, half-maximal cytotoxic concentration: 19 ug/mL
The estimate for compound 3 lay 1.2-fold (0.06 log units) above the measured number; measured number inside the range.
By their numbers in this assay, from the lowest: compounds 3, 2 and 1 (each within the scatter of the next).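

Ethyl in place of hydrogen on this saturated chain carbon, nine bonds along the chain from a saturated ring carbon, is a larger change than methyl, yet in this assay it gives a 1.7-fold lower number from compound 1 to compound 3 (0.24 log units; within the scatter) and so stays within the scatter. Methyl in place of hydrogen on a saturated chain carbon gives a 1.3-fold lower number from compound 2 to compound 3 (0.12 log units; within the scatter) and also stays within the scatter, so these three chain lengths cannot be told apart in this test. Nothing measured here offers an explanation for these numbers.

From the compounds shown here alone, whether a longer chain, or an amine or a carboxylic acid on this same chain carbon, would move the number beyond the scatter remains open. So does the effect of any change to the shared core.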